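From a Pyrazole Amide to a Lactam Amide

The source may hold more compounds than are shown below. What is called first, only, known or untested is meant among the compounds shown, and "the series" means these compounds.

Compound 1 `Cn1cc(CNS(=O)(=O)c2ccccc2Nc2cc(-c3ccc4ccn(C)c4c3)c3nccnc3c2)cn1` and compound 2 `Cn1cc(NC(=O)c2ccncc2Nc2cc(-c3ccc4ccn(C)c4c3)c3nccnc3c2)cn1` share one core. In an assay for inhibition of 6-phosphofructo-2-kinase/fructose-2,6-bisphosphatase 3 (Homo sapiens), read by ADP-Glo, with a stated time of 2 h (a lower number here means a stronger inhibitor, a higher number a weaker inhibitor), compound 1 gives 38 nM and compound 2 gives 33 nM; the two numbers lie within the scatter of each other, so neither stands apart. Compound 3 `CN1CC(NC(=O)c2ccncc2Nc2cc(-c3ccc4ccn(C)c4c3)c3nccnc3c2)CCC1=O` differs from compound 2 in one place: 1-methyl-6-oxopiperidin-3-yl in place of 1-methyl-1H-pyrazol-4-yl on an amide-type nitrogen. Among the measured compounds shown here, no measured pair shows this change, so nothing fixes its size. A step of a 1.8-fold higher number from compound 2 to compound 3 (0.26 log units; within the scatter) is expected, toward a somewhat higher number, hardly beyond the scatter. Compound 3 is estimated at 60 nM in this assay, with a range from 20 nM to 200 nM.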

Compound 3, half-maximal inhibitory concentration: 116 nM
For compound 3 the middle estimate is 1.9-fold (0.29 log units) below the measured one, within the range that was stated.
By their numbers in this assay, from the lowest: compounds 2 and 1 (each within the scatter of the next); then compound 3.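

In this assay, the group on this amide-type nitrogen clearly affects the result: 1-methyl-6-oxopiperidin-3-yl in place of 1-methyl-1H-pyrazol-4-yl brings a 3.5-fold higher number from compound 2 to compound 3 (0.55 log units; beyond the scatter) and so a weaker inhibitor. The earlier pair could not show this, as compound 1 and compound 2 differ in more than one place. Nothing at hand explains the rise. Which feature of the new ring matters remains open: a cyclohexyl or pyridinyl group on this nitrogen would help separate ring size, the carbonyl and aromaticity.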